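Two aryl substituents on the pyridazinone nitrogen and a third

The source may hold more compounds than are shown below. What is called first, only, known or untested is meant among the compounds shown, and "the series" means these compounds.

Compound 1 `Cc1cc(=O)n(-c2ccccc2C(F)(F)F)nc1C(=O)Nc1ccc(Oc2ncnc3ccsc23)cc1`: 8850 nM
Compound 2 `Cc1cc(=O)n(-c2ccc(F)cc2)nc1C(=O)Nc1ccc(Oc2ncnc3ccsc23)cc1`: 2360 nM

Within the data shown here, in a functional assay on A549 cells (Homo sapiens) for cytotoxicity, read by MTT assay, with a stated time of 72 h (on this read-out lower numbers stand for stronger inhibition and higher numbers for weaker inhibition), compound 2 gives the lowest of the two numbers in hand, the only neighbour being compound 1, which lies higher by the step of a 3.8-fold lower number from compound 1 to compound 2 (0.57 log units; beyond the scatter). Compound 3 `Cc1ccc(-n2nc(C(=O)Nc3ccc(Oc4ncnc5ccsc45)cc3)c(C)cc2=O)c(C)c1` differs from compound 2 in one place: 2,4-dimethylphenyl in place of 4-fluorophenyl on an aromatic nitrogen. Among the measured compounds shown here, only the single measured step bears on this change, and it showed that swapping one aryl group on that nitrogen for another moved the read-out by a modest but clear amount. Compound 3 carries a phenyl bearing two methyl groups, a pattern neither measured compound shares, so the direction is uncertain; a change of about the size already seen, toward a higher number, is expected, giving a 1.9-fold higher number from compound 2 to compound 3 (0.28 log units; within the scatter). Compound 3 is therefore estimated at 4500 nM, within 1500 nM to 13000 nM.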

Compound 3, half-maximal inhibitory concentration: 16400 nM
Beside the measured number, compound 3's estimate is 3.6-fold (0.56 log units) below it, outside the stated range (above it).
By their numbers in this assay, from the lowest: compound 2; then compounds 1 and 3 (each within the scatter of the next).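

In this assay, the step of a 6.9-fold higher number from compound 2 to compound 3 (0.84 log units; beyond the scatter) shows that the aryl group on this nitrogen can move the read-out in a second case, and that 2,4-dimethylphenyl, like 2-(trifluoromethyl)phenyl, goes with a higher number than 4-fluorophenyl. The step of a 1.9-fold higher number from compound 1 to compound 3 (0.27 log units; within the scatter) stays within the scatter, so among these three compounds only compound 2 stands apart, and fluorine alone does not mark it out, since compound 1 also carries fluorine in its trifluoromethyl group. Nothing available explains why the 4-fluorophenyl group stands apart.

The compounds shown leave open which of the two methyl groups of compound 3 goes with the step. A plain phenyl or a 4-methylphenyl on that nitrogen would speak to this, and a 4-aminophenyl would test a group of another kind there.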